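The source may hold more compounds than are shown below. What is called first, only, known or untested is meant among the compounds shown, and "the series" means these compounds.

Measured compounds in a functional assay on A549 cells (Homo sapiens) for cytotoxicity, read by MTT assay, with a stated time of 24 h; a lower number here means a stronger inhibitor, a higher number a weaker inhibitor:
Compound 1 `O=C(NN=C1CC(c2ccccc2)NC(c2ccccc2)C1)c1ccccc1` gives > 400000 nM, a limit of the assay.
Compound 2 `O=C(NN=C1CC(c2ccccc2)NC(c2ccccc2)C1)c1ccc(Cl)cc1` gives > 400000 nM, a limit of the assay.
Compound 3 `O=C(NN=C1CC(c2ccccc2)NC(c2ccccc2)C1)c1ccc(C(F)(F)F)cc1` gives > 400000 nM, a limit of the assay.

Compound 3 stands at the limit, where all three measured compounds sit (the limit of > 400000 nM in this assay, at which 3 of the 3 values shown sit). Compound 4 `O=C(NN=C1CC(c2ccccc2)NC(c2ccccc2)C1)c1ccc([N+](=O)[O-])cc1` differs from it by nitro in place of trifluoromethyl on an aromatic carbon. For the measured compounds named here, the steps that bear on this change are a step that the two limits leave unreadable from compound 1 to compound 3 and a step that the two limits leave unreadable from compound 2 to compound 3; both run between limits, so their size cannot be read, and a step that the two limits leave unreadable from compound 1 to compound 2 is unreadable in the same way. Going by the values given here, no measured step in this assay gives a direction to build on. Compound 4 is therefore expected to remain near the same limit, with a step that the limit leaves unreadable from compound 3 to compound 4 as the estimated step. The estimate for compound 4 is 500000 nM, in a range from 150000 nM to 2000000 nM.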

Compound 4, half-maximal inhibitory concentration: > 400000 nM
Compound 4: a limit, no number; the forecaster's own chance of this, stated with the estimate: 85%; the middle value is on the limit's open side.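

In this assay compound 4 gives > 400000 nM, a limit and not a number, and its steps to compound 1, compound 2 and compound 3 cannot be read. The compounds shown leave open whether any group at this place gives a readable value: the limit of > 400000 nM in this assay, at which 4 of the 4 values shown sit.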